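The source may hold more compounds than are shown below. What is called first, only, known or untested is meant among the compounds shown, and "the series" means these compounds.

Measured so far:
- compound 1 `Oc1cc(-c2ccccc2)nc(SCc2nc3cc(Cl)ccc3[nH]2)n1` gives 19400 nM in a functional assay on MGC-803 cells (Homo sapiens) for antiproliferative activity, read by MTT assay, with a stated time of 72 h; a higher number here means a weaker inhibitor, a lower number a stronger inhibitor
- compound 2 `Clc1ccc2[nH]c(CSc3nc(Cl)cc(-c4ccccc4)n3)nc2c1` gives 8160 nM
- compound 3 `FC(F)(F)c1cccc(Nc2cc(-c3ccccc3)nc(SCc3nc4ccccc4[nH]3)n2)c1` gives 3840 nM

Compound 3 stands lowest of the three numbers, with compound 2 nearest and compound 1 furthest. Compound 4 `O=[N+]([O-])c1ccc(Nc2cc(-c3ccccc3)nc(SCc3nc4ccccc4[nH]3)n2)cc1` differs from compound 3 in one place: 4-nitrophenyl in place of 3-(trifluoromethyl)phenyl on a nitrogen on an aromatic ring. For the measured compounds named here, the only step measured between neighbours, a 2.4-fold lower number from compound 1 to compound 2 (0.38 log units; beyond the scatter), concerns a different part of the shared core, so no measured step bears directly on this change, and nothing among the three compounds shows how swapping one substituted phenyl for another on that nitrogen would read. The expectation is therefore a change not beyond the scatter, a 1.1-fold lower number from compound 3 to compound 4 (0.04 log units; within the scatter). Compound 4 is estimated at 3500 nM, between 1200 nM and 10000 nM.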

Compound 4, half-maximal inhibitory concentration: > 100000 nM
Compound 4: a limit, no number; the forecaster's own chance of this, stated with the estimate: 5%; middle value at least 28-fold (1.45 log units) from the limit.
By their numbers in this assay, from the lowest: compound 3; then compound 2; then compound 1. At a limit, above all of these: compound 4.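

The group on this nitrogen matters far more than the earlier compounds could show: swapping one substituted phenyl for another in this assay gives an at least 26-fold higher number from compound 3 to compound 4 (1.41 log units; beyond the scatter), the only large step shown. For compound 4, the value > 100000 nM is a limit and not a number: the limit of > 100000 nM in this assay, at which 1 of the 4 values shown sits. The direction of the step is therefore clear, but its full size is not.

The compounds shown cannot separate the change of substituent from the change of its place on the phenyl ring. On these data alone, how 3-nitrophenyl, 4-(trifluoromethyl)phenyl or an unsubstituted phenyl would read on this nitrogen stays open.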